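A few compounds are considered here, and "the series" means these few. Any claim that something is new, unique, unknown or untested is made for them only; others in the source may bear on it.

Measured compounds:
compound 1, `CC(NC(=O)CN)C(=O)N(C)c1ccc(Cl)cc1C(=O)c1ccccc1Cl`: 0.47 mg/kg
compound 2, `CC(C)C(=O)NCC(=O)N(C)c1ccc(Cl)cc1C(=O)c1ccccc1Cl`: 6 mg/kg
compound 3, `CN(C(=O)CNC(=O)c1ccccc1)c1ccc(Cl)cc1C(=O)c1ccccc1`: 7.6 mg/kg

All three were tested in a functional assay on the whole organism for antagonist activity, with Mus musculus as the target; a higher number here means that more compound is needed for the effect, a lower number that less compound is needed. Compound 2 stands second highest of the three numbers; its value and that of compound 3 lie within the usual scatter of each other, so no order between them can be read. Against compound 1 the gap is large: a 13-fold higher number from compound 1 to compound 2 (1.11 log units; beyond the scatter), a step that alters the acyl group and the carbon bearing the methyl at once.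

Compound 4, `CC(=O)NCC(=O)N(C)c1ccc(Cl)cc1C(=O)c1ccccc1Cl`, has not yet been measured. Its difference from compound 2 is methyl in place of isopropyl on a carbonyl carbon.

Among the measured compounds shown here, only the step from compound 1 to compound 2 bears on the acyl side of the shared core, and it mixes two changes, so it gives no clean precedent for trading isopropyl for methyl alone. No direct comparison of acyl chain size exists among the measured compounds. The expectation is therefore a step of a 1.5-fold lower number from compound 2 to compound 4 (0.18 log units; within the scatter), within the scatter, with no direction claimed beyond it. Compound 4 is estimated at 4 mg/kg, in the range 1.5 mg/kg to 12 mg/kg.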

Compound 4, dose for half-maximal effect: 2.3 mg/kg
For compound 4 the middle estimate is 1.7-fold (0.24 log units) above the measured one; the measured number falls inside the stated range.
By their numbers in this assay, from the lowest: compound 1; then compound 4; then compounds 2 and 3 (each within the scatter of the next).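

In this assay the acyl group now has a single clean change: methyl in place of isopropyl on a carbonyl carbon gives a 2.6-fold lower number from compound 2 to compound 4 (0.42 log units; beyond the scatter) as its step, so this position responds to that exchange alone, which the mixed step from compound 1 could not show. The acetamidomethyl compound still leaves a 4.9-fold higher number from compound 1 to compound 4 (0.69 log units; beyond the scatter) as its gap, smaller than the gap printed for the isopropyl compound, and this step still changes the acyl end and the methyl-bearing carbon at once. No evidence on the cause of either step is at hand.

As far as these compounds go, two acyl groups give no trend, so the effect of a longer chain such as butyl, or of a cyclopropyl or a carboxylic acid on the same carbonyl carbon, remains open. The separate contributions of the terminal amine and the methyl-bearing carbon also remain unresolved.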